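Adding a Second Phenyl Ring to Compound 1

A few compounds are considered here, and "the series" means these few. Any claim that something is new, unique, unknown or untested is made for them only; others in the source may bear on it.

Compound 1 `CNCc1nnc(-c2ccccc2)s1` was tested in a functional assay on the whole organism with Mus musculus as the target; a lower number here means that less compound is needed, a higher number that more compound is needed for the effect. In this assay compound 1 gives only a limit, > 200 mg/kg, which is the edge of what the assay reports and not a measured number. Compound 2 `Cc1ccccc1NCc1nnc(-c2ccccc2-c2ccccc2)s1` was tested the same way. In this assay compound 2 likewise gives only a limit, > 200 mg/kg. Going by the values given here, both known values sit at the limit of > 200 mg/kg in this assay, at which 2 of the 2 values shown sit, so no measured step between them can be sized, and nothing can be said about how one compares with the other.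

Compound 3 `CNCc1nnc(-c2ccccc2-c2ccccc2)s1` has not yet been measured. It differs from compound 1 in a single place: phenyl in place of hydrogen on an aromatic carbon, in short phenyl in place of hydrogen on an aromatic carbon. Among the compounds with values here, with no measured step to lean on and both known values at the limit, the estimated step that the limit leaves unreadable from compound 1 to compound 3 is expected to be none beyond the usual scatter. Compound 3 is therefore expected to give about 300 mg/kg in this assay, within a range from 100 mg/kg to 1000 mg/kg, and most likely once more only a limit rather than a number.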

Compound 3, dose for half-maximal effect: 20 mg/kg
The estimate for compound 3 lay 15-fold (1.18 log units) above the measured number, and the stated range ends above it.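

Phenyl in place of hydrogen on an aromatic carbon, ortho to a group of 8 heavy atoms, is the first change among these compounds to yield a real number rather than a limit: in this assay it gives an at least 10-fold lower number from compound 1 to compound 3 (1.00 log units; beyond the scatter). The added phenyl is not enough on its own, since compound 2 carries it as well, and methyl in place of 2-methylphenyl on an amine nitrogen gives an at least 10-fold lower number from compound 2 to compound 3 (1.00 log units; beyond the scatter). Both changes therefore matter in this series, and each step can be stated only as a minimum because its starting compound sits at a limit: the limit of > 200 mg/kg in this assay, at which 2 of the 3 values shown sit.

The compounds shown leave open whether a smaller group, such as methyl or a chlorine atom, would have a similar effect on that aromatic carbon, or whether a phenyl ring is needed there. They also leave open how far the amine nitrogen tolerates change, as an ethyl group or a longer chain in place of the methyl could move the number in this assay either way.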